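Replacing pyridin-3-yl with 2,4-difluorophenyl: expected cell tolerance

This account rests on a few compounds, and the source may have more. Where it says the series, first, only, none or still open, it means among the compounds named here.

Compound 1 `COC(=O)c1cc(-c2cccc(NC(=O)c3ccc(/C=C/C(=O)c4cccnc4)cc3)c2)on1`: "not determined" (no result reported)
Compound 2 `COC(=O)c1cc(-c2cccc(NC(=O)c3ccc(/C=C/C(=O)c4cccc(C(F)(F)F)c4)cc3)c2)on1`: > 20 ug/mL
Compound 3 `COC(=O)c1cc(-c2cccc(NC(=O)c3ccc(/C=C/C(=O)c4ccc(Cl)cc4Cl)cc3)c2)on1`: > 40 ug/mL

All three were run in an ADME assay on Vero cells (Chlorocebus sabaeus) for cytotoxicity, read by MTT assay, with a stated time of 72 h; a higher number here means that more compound is tolerated, a lower number that less compound is tolerated. For compound 1 no number exists: in this assay compound 1 gives "not determined" (no result reported). Compound 2 stopped at a limit of this assay, > 20 ug/mL. Compound 3 also stopped at a limit, > 40 ug/mL. Between them lies a step that the two limits leave unreadable from compound 2 to compound 3, so its size stays unknown.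

Compound 4 `COC(=O)c1cc(-c2cccc(NC(=O)c3ccc(/C=C/C(=O)c4ccc(F)cc4F)cc3)c2)on1` differs from compound 1 in one place: 2,4-difluorophenyl in place of pyridin-3-yl on a carbonyl carbon. For the measured compounds named here, no measured step bears on this change; the only recorded step is unreadable, so no direction beyond the scatter can be expected. Since the neighbours sit at the limit of > 20 ug/mL in this assay, at which 1 of the 3 values shown sits, and (the limit of > 40 ug/mL in this assay, at which 1 of the 3 values shown sits), compound 4 is likewise expected to be well tolerated. Compound 4 is estimated at 40 ug/mL, with a range from 20 ug/mL to 80 ug/mL.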

Compound 4, half-maximal cytotoxic concentration: > 40 ug/mL
Compound 4: a limit, no number; the forecaster's own chance of this, stated with the estimate: 80%; the middle value lies on the limit itself.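

In this assay compound 4 gives > 40 ug/mL, a limit and not a number, and its steps from compound 2 and compound 3 cannot be read. The compounds shown leave open at what concentration compound 2, compound 3 and compound 4 harm these cells, and whether they differ at all.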